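The source may report more compounds than this note shows. Statements on the series, on what has been measured and on what is new or still open speak of the compounds shown alone.

Measured compounds:
- compound 1, `CC/N=C(/NC#N)NCCCn1nc(-c2ccccc2)ccc1=O`, in a functional assay on the whole organism with Rattus norvegicus as the target, at a dose of 100 mg/kg; on this read-out higher numbers stand for more inhibition at the one dose given (going by the name of the read-out) and lower numbers for less inhibition: 62.9%
- compound 2, `CN(C)/C(=N/CCCn1nc(-c2ccccc2)ccc1=O)NC#N`, in this assay: 72.2%

Among these two numbers compound 2 stands highest, with compound 1 nearest, the two within the scatter of each other. Compound 3, `C/N=C(\S)NCCCn1nc(-c2ccccc2)ccc1=O`, is not yet measured. It differs from compound 2 in one place: a group of 5 heavy atoms (2 carbon, 2 nitrogen, 1 sulfur; no ring) in place of a group of 8 heavy atoms (4 carbon, 4 nitrogen; no ring), on a saturated chain carbon, three bonds along the chain from an aromatic nitrogen. Among the measured compounds shown here, the one measured step that bears on this position is a number 9.3 percentage points higher from compound 1 to compound 2 (within the scatter), which changed the number by a small amount. For the measured compounds named here, no measured step shows the group that enters here. Because a number 9.3 percentage points higher from compound 1 to compound 2 (within the scatter) was within the scatter, compound 3 is expected to stay near compound 2, and the estimated step of a number 10.2 percentage points lower from compound 2 to compound 3 (beyond the scatter) is small. For compound 3 the estimate in this assay is 62%, with a range from 35% to 85%.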

Compound 3, a percentage reported as inhibition, in the whole organism at one dose (the size of the read-out at that dose, not a potency): 38.9%
Beside the measured number, compound 3's estimate is 23.1 percentage points above it, within the range that was stated.
By their numbers in this assay, from the lowest: compound 3; then compounds 1 and 2 (each within the scatter of the next).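

The position on the saturated chain carbon, three bonds along the chain from an aromatic nitrogen, now proves sensitive to its group: the earlier pair stayed within the scatter, but in this assay the sulfur-bearing group gives a number 33.3 percentage points lower from compound 2 to compound 3 (beyond the scatter) and, against the other earlier compound, a number 24 percentage points lower from compound 1 to compound 3 (beyond the scatter). So the change matters at this position whichever of the two earlier groups it replaces. No measurement here explains the fall. On these data alone, it remains open whether the sulfur itself accounts for the drop, and whether a urea, with oxygen in place of the sulfur, would keep the higher numbers.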